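A few compounds are considered here, and "the series" means these few. Any claim that something is new, unique, unknown or untested is made for them only; others in the source may bear on it.

Measured compounds:
compound 1, `CCCc1nc(C)c2c(C)nn(CCC)c(=O)n12`: > 48000 nM
compound 2, `C=CCn1ncc2cnc(C)n2c1=O`: > 48000 nM

Both entries are limits of the assay rather than numbers. In a functional assay for inhibition, with Homo sapiens as the target (a higher number here means a weaker inhibitor, a lower number a stronger inhibitor), compound 1 gives only a limit, > 48000 nM. Compound 2 in this assay likewise gives only a limit, > 48000 nM. Compound 1 therefore stands at the edge of what this assay resolves, and it does not stand there alone: the limit of > 48000 nM in this assay, at which 2 of the 2 values shown sit. Among the measured compounds shown here, no step between two measured compounds can be read from these data, since compound 1 and compound 2 do not differ in a single place.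

Compound 3, `CCCc1nc(C)c2c(C)nn(CC)c(=O)n12`, is not yet measured in this assay. It differs from compound 1 in one place:

hydrogen in place of methyl on a saturated chain carbon, two bonds along the chain from an aromatic nitrogen

A change of this kind, propyl to ethyl on the chain carried by the aromatic nitrogen, gives little reason to expect movement from a compound that already sits at the limit. The step that the limit leaves unreadable from compound 1 to compound 3 is expected to be none beyond the scatter. Compound 3 is accordingly expected to come out near 80000 nM, somewhere between 30000 nM and 300000 nM, most probably reported once more as a limit rather than a number.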

Compound 3, half-maximal inhibitory concentration: > 48000 nM
Compound 3 ended at the assay's limit; the forecaster's own chance of this, stated with the estimate: 85%; the middle value is on the limit's open side.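

Compound 3, like compound 1, gives only a limit in this assay, so the change from propyl to ethyl yields no step that can be read between the two compounds: the limit of > 48000 nM in this assay, at which 3 of the 3 values shown sit.

The compounds shown leave open how far past that limit each one lies, and which change to the shared core, if any, would give a value readable as a number.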